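The source may hold more compounds than are shown below. What is called first, only, known or untested is meant among the compounds shown, and "the series" means these compounds.

Compound 1 `O=C1/C(=C/c2ccc(O)cc2)S/C(=N\c2ccccc2)N1Cc1ccco1` gives > 250000 nM
Compound 2 `CC(C)Oc1ccc(/C=C2\S/C(=N\c3ccccc3)N(Cc3ccco3)C2=O)cc1` gives "not determined" (no result reported)

Compound 1 reads > 250000 nM in a toxicity assay on CHO cells (Cricetulus griseus) for cytotoxicity, read by MTT assay, with a stated time of 72 h (a lower number here means a stronger inhibitor, a higher number a weaker inhibitor), and this is a limit of the assay, not a number. Compound 3 `COc1ccc(/C=C2\S/C(=N\c3ccccc3)N(Cc3ccco3)C2=O)cc1` carries methyl in place of hydrogen on an oxygen on an aromatic ring so that 4-hydroxyphenyl becomes 4-methoxyphenyl. For the measured compounds named here, no measured pair shows what this swap does, so the expected step of an at least 1.2-fold lower number from compound 1 to compound 3 (0.09 log units; that floor lies within the scatter) is no larger than the usual scatter, and another limit reading would be no surprise. For compound 3 the estimate is 200000 nM with an expected range from 70000 nM to 300000 nM in this assay for now.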

Compound 3, half-maximal inhibitory concentration: > 250000 nM
Compound 3 gave a limit, no number; the forecaster's own chance of this, stated with the estimate: 60%; middle value at least 1.2-fold (0.09 log units) away from the limit.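

Compound 1 and compound 3 both give only a limit, not a number, so no step between them can be read: the limit of > 250000 nM in this assay, at which 2 of the 3 values shown sit.

From the compounds shown here alone, how far either compound lies past that limit, and so what 4-methoxyphenyl in place of 4-hydroxyphenyl does, stays open.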